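Swapping a Side Chain and Watching Liver Clearance

The compounds below may be only part of what the source reports. "The series", "measured", "known", "first", "only" and "open" are said of these compounds alone.

Measured compounds:
compound 1 `COC(=O)C1=C(C)NC(c2nccs2)=NC1(C)c1ccc(F)c(F)c1`: 83 mL/min/kg
compound 2 `COC(=O)C1=C(CN2CCNC(=O)C2)NC(c2nccs2)=NC1(C)c1ccc(F)cc1`: 81 mL/min/kg
compound 3 `COC(=O)C1=C(CN2CCC(O)CC2)NC(c2nccs2)=NC1(C)c1ccc(F)cc1`: 81 mL/min/kg

In an ADME assay on microsomes from liver (Mus musculus) for metabolic stability, read by LC-MS, using NADPH, with stated times of 10 min and 30 min, tested at 1 uM (on this read-out lower numbers stand for slow clearance and higher numbers for fast clearance), compound 2 gives 81 mL/min/kg. On these numbers compound 2 stands level with compound 3, and the two together are the lowest of the three values; compound 1 is the furthest away, yet its number lies within the scatter of compound 2, so the three compounds cannot be told apart on this read-out.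

Compound 4 `COC(=O)C1=C(COCC(F)(F)F)NC(c2nccs2)=NC1(C)c1ccc(F)cc1` is built from compound 2 by one change: 2,2,2-trifluoroethoxy in place of 3-oxopiperazin-1-yl on a saturated chain carbon bound to a double-bonded ring carbon. Among the compounds with values here, only one measured step touches the same place on the core, the step of no change at the digits printed from compound 2 to compound 3 (within the scatter), and it brought no change beyond the scatter. That step exchanged one ring-bearing group for another; the change to compound 4 instead removes the ring and brings in a 2,2,2-trifluoroethoxy group, for which no measured comparison exists. Within the data shown here, the only evidence therefore points to no step beyond the scatter in this assay, while leaving room for a real difference in either direction.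

Compound 4 is expected to give about 80 mL/min/kg in this assay, between 45 mL/min/kg and 145 mL/min/kg. The estimated step from compound 2 to compound 4 is a 1.0-fold lower number from compound 2 to compound 4 (0.01 log units; within the scatter).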

Compound 4, clearance: 81 mL/min/kg
Beside the measured number, compound 4's estimate is 1.0-fold (0.01 log units) below it; measured number inside the range.
By their numbers in this assay, from the lowest: compounds 2, 3, 4 and 1 (each within the scatter of the next).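

In this assay, replacing the ring-bearing side chain with an open chain gives no change at the digits printed from compound 2 to compound 4 (within the scatter), and the second comparison gives no change at the digits printed from compound 3 to compound 4 (within the scatter). Within the data shown here, the earlier step exchanged only one ring for another, whereas these steps show that on a saturated chain carbon bound to a double-bonded ring carbon, 2,2,2-trifluoroethoxy, with no ring and 0 hydrogen-bond donors, reads the same as both ring groups. Nothing available explains why the read-out is the same across these three different groups.

Still open, as far as these compounds go, is whether any group at this place can move the number at all, such as a carboxylic acid, a dimethylamino group or a longer alkyl chain. The compounds shown also leave open whether replacing the methyl ester on the shared core would do so.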